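A new ring on the sulfonyl sulfur of compound 3

The source may hold more compounds than are shown below. What is called first, only, known or untested is meant among the compounds shown, and "the series" means these compounds.

Measured compounds:
- compound 1 `CCc1c(C(=O)NCc2c(O)ccc3cccc(O)c23)[nH]c(C)c1C(C)=O`: 4200 nM
- compound 2 `CCN(CC)S(=O)(=O)c1ccc(OC)c(NC(=O)c2[nH]c(C)c3c2CCCCC3=O)c1`: 6840 nM
- compound 3 `COc1ccc(S(=O)(=O)N2CC3(COC3)C2)cc1NC(=O)c1[nH]c(C)c2c1CCCCC2=O`: 5760 nM

In a functional assay on MCF7 cells (Homo sapiens) for inhibition, with a stated time of 72 h (a higher number here means a weaker inhibitor of growth, a lower number a stronger inhibitor of growth), compound 3 gives 5760 nM, which lies within the usual scatter of both other measured compounds, so the three cannot be ranked against it. Compound 4 `COc1ccc(S(=O)(=O)N2CCCCCC2)cc1NC(=O)c1[nH]c(C)c2c1CCCCC2=O` keeps the core of compound 3 and puts an azepan-1-yl group on the sulfonyl sulfur: a group of 7 heavy atoms (6 carbon, 1 nitrogen; one seven-membered non-aromatic ring with 1 hetero atom) in place of a group of 7 heavy atoms (5 carbon, 1 nitrogen, 1 oxygen; 2 four-membered non-aromatic rings with 1 hetero atom each), on a sulfonyl sulfur. Among the measured compounds shown here, only one measured step bears on this exchange, since it concerns the same sulfonyl sulfur: a 1.2-fold lower number from compound 2 to compound 3 (0.07 log units; within the scatter). That step stays within the scatter, even though the two groups involved look quite different. Compound 1 is not linked to compound 3 by a change in one place, so it offers no such guide. For the measured compounds named here, no measured compound carries azepan-1-yl, so this is a modest basis, and no step beyond the scatter is expected in this assay. The estimated step is a 1.2-fold lower number from compound 3 to compound 4 (0.06 log units; within the scatter). Compound 4 is expected to give about 5000 nM, within an estimated range of 2500 nM to 10000 nM.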

Compound 4, concentration for 50% growth inhibition: 3000 nM
Estimate against measurement, compound 4: 1.7-fold (0.22 log units) above, within the range that was stated.
By their numbers in this assay, from the lowest: compounds 4, 1, 3 and 2 (each within the scatter of the next, the first and the last beyond it).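

In this assay, the group on the sulfonyl sulfur now gives its first step beyond the scatter: azepan-1-yl in place of diethylamino is a 2.3-fold lower number from compound 2 to compound 4 (0.36 log units; beyond the scatter), though this is a modest result. The other new step, a 1.9-fold lower number from compound 3 to compound 4 (0.28 log units; within the scatter), stays within the scatter, so the two ring groups of compound 3 and compound 4 cannot be ranked against each other, even though one is a single large ring and the other two small rings. Nothing measured here explains why azepan-1-yl and diethylamino differ.

Still open, going by these compounds, is whether any ring on this sulfur would give the same result as azepan-1-yl, or whether it depends on that ring. A pyrrolidin-1-yl or piperidin-1-yl group at the same place would test this.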